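The source may report more compounds than this note shows. Statements on the series, on what has been measured and on what is new or still open speak of the compounds shown alone.

Working notes on the series.

Going by the values given here, compound 3 `CC/N=C(/NC#N)NCCCCCCn1nc(-c2ccccc2)ccc1=O` gives the lowest of the three numbers so far in a functional assay on the whole organism with Rattus norvegicus as the target, at a dose of 100 mg/kg; a lower number here means less inhibition, a higher number more inhibition at the dose given (going by the name of the read-out): compound 3 gives 29.1%. Its nearest neighbour is compound 2 `C/N=C(/NC#N)NCCCCCCn1nc(-c2ccccc2)ccc1=O`, which in this assay gives 31.7%; the step of a number 2.6 percentage points lower from compound 2 to compound 3 (within the scatter) is within the scatter. The furthest is compound 1 `CC/N=C(\S)NCCCCCn1nc(-c2ccccc2)ccc1=O`, which in this assay gives 66.4%; the step of a number 37.3 percentage points lower from compound 1 to compound 3 (beyond the scatter) is beyond the scatter, as is a number 34.7 percentage points lower from compound 1 to compound 2 (beyond the scatter).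

Compound 4 `CN(C)/C(=N/CCCCCCn1nc(-c2ccccc2)ccc1=O)NC#N` is not yet measured. Compared with compound 3 the change is a group of 8 heavy atoms (4 carbon, 4 nitrogen; no ring) in place of a group of 8 heavy atoms (4 carbon, 4 nitrogen; no ring), on a saturated chain carbon, six bonds along the chain from an aromatic nitrogen. Among the compounds with values here, no measured step rearranges the group at the chain end in this way. Within the data shown here, the only step confined to that group, a number 2.6 percentage points lower from compound 2 to compound 3 (within the scatter), was within the scatter; the two large steps from compound 1 exchange a different group and do not bear on this change. The expectation is therefore no step beyond the scatter, and the estimate for compound 4 in this assay is 30%, with a range from 15% to 47%, an expected step of a number 0.9 percentage points higher from compound 3 to compound 4 (within the scatter).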

Compound 4, a percentage reported as inhibition, in the whole organism at one dose (the size of the read-out at that dose, not a potency): 58.4%
For compound 4 the middle estimate is 28.4 percentage points below the measured one; measured number outside the range, above it.
By their numbers in this assay, from the lowest: compounds 3 and 2 (each within the scatter of the next); then compounds 4 and 1 (each within the scatter of the next).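

At the chain end, on a saturated chain carbon, six bonds along the chain from an aromatic nitrogen, the same atoms joined differently are enough to shift this assay, with a number 29.3 percentage points higher from compound 3 to compound 4 (beyond the scatter) and with a number 26.7 percentage points higher from compound 2 to compound 4 (beyond the scatter) beside it. Going by these compounds alone, the only earlier step confined to this group was within the scatter, so this is the first sign that the arrangement of the group matters, the entering group having 1 hydrogen-bond donor where the leaving group has 2. With a number 8 percentage points lower from compound 1 to compound 4 (within the scatter) as the remaining step, compound 4 cannot be told apart from compound 1 in this read-out, despite the different group and place.

Nothing available gives a reason for the step from compound 3 to compound 4. On these data alone, it remains open whether a piperidine ring at the chain end or a longer chain would keep the number of compound 4.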